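Alkoxy acetophenone series: chain extension and inhibition

The compounds below may be only part of what the source reports. "The series", "measured", "known", "first", "only" and "open" are said of these compounds alone.

Measured so far:
Compound 1, `CCCCCCCCCCOc1cc(OC)c(Br)cc1C(C)=O`, in a functional assay, with stated times of 30 s and 6 min, in the presence of a further agent that is not named here (on this read-out lower numbers stand for stronger inhibition and higher numbers for weaker inhibition), gives 15000000 nM.
Compound 2, `CCCCCCCCCCCCOc1cc(OC)c(Br)cc1C(C)=O`, in this assay gives 10600000 nM.
Compound 3, `CCCCCCOc1cc(OC)ccc1C(C)=O`, in this assay gives 18000000 nM.

Compound 1 and compound 2 share a core and differ by ethyl in place of hydrogen on a saturated chain carbon, ten or more bonds along the chain from an oxygen on an aromatic ring. The step of a 1.4-fold lower number from compound 1 to compound 2 (0.15 log units; within the scatter) is within the scatter, so no change in inhibition is read from it. Compound 3 carries a different core; the difference between the two cores is not broken down here. Compound 3 and compound 1 are within scatter of each other, as are compound 3 and compound 2.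

Compound 4, `CCCCCCCCOc1cc(OC)ccc1C(C)=O`, is not yet measured. It differs from compound 3 by ethyl in place of hydrogen on a saturated chain carbon, six bonds along the chain from an oxygen on an aromatic ring. This is the same kind of change as that from compound 1 to compound 2, but the place differs: the chain carbon that carries the change lies at a different distance along the chain from the oxygen on the aromatic ring in the two pairs, as the two differences described above show. The expected step, a 1.3-fold lower number from compound 3 to compound 4 (0.11 log units; within the scatter), rests on the earlier step of a 1.4-fold lower number from compound 1 to compound 2 (0.15 log units; within the scatter). Compound 4 is therefore expected to give 14000000 nM, estimated between 7000000 nM and 30000000 nM.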

Compound 4, half-maximal inhibitory concentration: 21200000 nM
Compound 4: the middle estimate sits 1.5-fold (0.18 log units) below what was measured; the measured number falls inside the stated range.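

In this assay, the new step is a 1.2-fold higher number from compound 3 to compound 4 (0.07 log units; within the scatter), so ethyl in place of hydrogen on a saturated chain carbon reads as no change in inhibition on the core of compound 3. Set beside the earlier step, the same change gives no readable difference between the two cores: the same change on two cores in this assay, a 1.4-fold lower number (0.15 log units; within the scatter) from compound 1 to compound 2 and a 1.2-fold higher number (0.07 log units; within the scatter) from compound 3 to compound 4, 1.7-fold (0.22 log units) apart, within the scatter of two such steps This shows only that the change leaves the number within the scatter in both pairs; with neither step beyond the scatter, it does not show that a real effect carries from one core to the other, and core and place along the chain are not separated, as the carbon that carries the change differs between the pairs.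

The compounds shown leave open whether a longer chain on the core of compound 3 would give a step beyond the scatter. They also leave open what an amine or a carboxylic acid on the chain would do to inhibition on either core.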